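The source may report more compounds than this note shows. Statements on the series, on what has been measured and on what is new or still open speak of the compounds shown alone.

Measured compounds in a functional assay on HeLa cells (Homo sapiens) for inhibition, read by MTT assay; a lower number here means a stronger inhibitor, a higher number a weaker inhibitor:

compound 1 `Cc1ccc2c(c1)/C(=N/NC(=S)N/N=C/c1ccccn1)C(=O)N2`: 3150 nM
compound 2 `O=C1Nc2ccc(Br)cc2/C1=N/NC(=S)N/N=C/c1ccc(Br)cc1`: 4680 nM
compound 3 `COc1ccc(/C=N/NC(=S)N/N=C2\C(=O)Nc3ccc(C)cc32)c(OC)c1`: > 50000 nM, a limit of the assay, not a number

Compound 2 carries the highest of the two numbers read in this assay; the nearest is compound 1, whose value lies within the scatter of compound 2, so no order between the two can be claimed. Compound 3 stands at the limit only; no number is known for it. That limit is the limit of > 50000 nM in this assay, at which 1 of the 3 values shown sits.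

Compound 4 `COc1ccc(/C=N/NC(=S)N/N=C2\C(=O)Nc3ccc(Br)cc32)cc1O` is not yet measured. It differs from compound 2 in one place: 3-hydroxy-4-methoxyphenyl in place of 4-bromophenyl on a carbon with a double bond to nitrogen. Among the measured compounds shown here, no pair of measured compounds shows this change alone, so its size is not known from the data. For the measured compounds named here, both numbered compounds sit in the low micromolar range, and the one compound whose aryl carries oxygen substituents, compound 3, sits at the limit. The step from compound 2 to compound 4 is therefore expected to go toward a higher number, beyond the scatter, with a real chance that only a limit is read. Compound 4 is estimated at 20000 nM, with a range of 6000 nM to 60000 nM. This estimate means a step of a 4.3-fold higher number from compound 2 to compound 4 (0.63 log units; beyond the scatter).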

Compound 4, half-maximal inhibitory concentration: 2220 nM
The estimate for compound 4 lay 9.0-fold (0.95 log units) above the measured number, and the stated range ends above it.
By their numbers in this assay, from the lowest: compounds 4, 1 and 2 (each within the scatter of the next, the first and the last beyond it). At a limit, above all of these: compound 3.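

In this assay, among the compounds shown here, putting 3-hydroxy-4-methoxyphenyl in place of 4-bromophenyl on a carbon with a double bond to nitrogen gives a 2.1-fold lower number from compound 2 to compound 4 (0.32 log units; beyond the scatter), the only single-place change that can be read. This position therefore accepts an aryl group carrying oxygen substituents with no loss in this assay, and the replacement of bromine by these groups goes toward the lower number, though only modestly. Compound 3 also carries oxygen substituents on its aryl group, but it differs from compound 4 in more than one place and its entry is a limit of the assay, not a number, so it gives no reading of this change: the limit of > 50000 nM in this assay, at which 1 of the 4 values shown sits.

All other pairs among the compounds shown differ in more than one place, so their steps cannot be read, and the part played by the methyl or bromine on the core stays unresolved. Also open, as far as these compounds go, is whether the hydroxy or the methoxy alone carries the step, and how an amine or a carboxylic acid on that aryl group would read at this position.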